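Methoxymethyl replaced on the carbonyl carbon of compound 2

The compounds below may be only part of what the source reports. "The series", "measured", "known", "first", "only" and "open" are said of these compounds alone.

Among the compounds with values here, in a functional assay on A2780 cells (Homo sapiens) for antiproliferative activity, read by CellTiter-Glo, with a stated time of 4 days (a higher number here means a weaker inhibitor, a lower number a stronger inhibitor), compound 1 `CCC(=O)N[C@@H](C)c1ccc(NC(=O)[C@H]2C[C@@H]2c2cccnc2)cc1` gives 5 nM, and compound 2 `COCC(=O)N[C@@H](C)c1ccc(NC(=O)[C@H]2C[C@@H]2c2cccnc2)cc1` gives 30 nM, the higher of the two numbers so far. Compound 3 `C[C@H](NC(=O)[C@@H]1CCCN1C)c1ccc(NC(=O)[C@H]2C[C@@H]2c2cccnc2)cc1` carries 1-methylpyrrolidin-2-yl in place of methoxymethyl on a carbonyl carbon. Within the data shown here, only one measured step bears on this change: a 6.0-fold higher number from compound 1 to compound 2 (0.78 log units; beyond the scatter), modest but beyond the scatter, made on the same acyl chain. It shows that this part of the molecule can shift the number in this assay, though one step sets no trend, and neither measured compound has a ring here. Compound 3 also lacks the methoxymethyl group of compound 2, so a small move toward a lower number is expected, with either direction possible. The expected step is a 1.5-fold lower number from compound 2 to compound 3 (0.18 log units; within the scatter). For compound 3 the estimated value is 20 nM, with an expected range of 4 nM to 100 nM.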

Compound 3, half-maximal inhibitory concentration: 1 nM
Compound 3: middle estimate off by 20-fold (1.30 log units), on the high side, outside the stated range (below it).
By their numbers in this assay, from the lowest: compound 3; then compound 1; then compound 2.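

Within the data shown here, at this position on a carbonyl carbon a ring is not only accepted but gives the lowest number so far: in this assay 1-methylpyrrolidin-2-yl in place of methoxymethyl gives a 30-fold lower number from compound 2 to compound 3 (1.48 log units; beyond the scatter) and in place of ethyl gives a 5.0-fold lower number from compound 1 to compound 3 (0.70 log units; beyond the scatter). The earlier pair showed only a rise in the number on moving between open chains, whereas this change shows that the group here can also move the number well below that of the better chain. The gain therefore does not depend on staying with a small open chain, and no measurement given here accounts for it.

On these data alone, whether the step belongs to the ring, its nitrogen, the methyl on that nitrogen or the defined stereocentre remains open. The unmethylated pyrrolidin-2-yl, the opposite stereoisomer and an open-chain amine such as dimethylaminomethyl would separate these parts.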